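Expected Cytotoxicity of a Difluorophenyl Amide Analogue

The compounds below may be only part of what the source reports. "The series", "measured", "known", "first", "only" and "open" are said of these compounds alone.

Compound 1 `CC(C)n1ncc2c(C(=O)Nc3c(F)cc(F)cc3F)cc(-c3cccs3)nc21`: > 200000 nM
Compound 2 `CC(C)n1ncc2c(C(=O)Nc3ccccn3)cc(C3CC3)nc21`: 25000 nM
Compound 3 `CC(C)n1ncc2c(C(=O)Nc3ccccc3F)cc(-c3ccccn3)nc21`: 100000 nM

All three share one core and were tested in an ADME assay on LLC-MK2 cells (Macaca mulatta) for cytotoxicity, read by spectrophotometry and crystal violet staining, with a stated time of 4 days; on this read-out higher numbers stand for lower toxicity in this test and lower numbers for higher toxicity in this test. Compound 1 gives only a limit of the assay, > 200000 nM, and stands at the limit of > 200000 nM in this assay, at which 1 of the 3 values shown sits. Compound 2 gives 25000 nM. Compound 3 gives 100000 nM. Compound 4 `CC(C)n1ncc2c(C(=O)Nc3cc(F)ccc3F)cc(-c3cccs3)nc21` has not yet been tested. It differs from compound 1 in one place: 2,5-difluorophenyl in place of 2,4,6-trifluorophenyl on an amide-type nitrogen. Among the compounds with values here, no measured pair differs in a single place, so no step size can be read from the data. In this assay the change is expected to shift toxicity by little, if at all, beyond the scatter, with a step of a number no higher from compound 1 to compound 4 (the limit leaves the size open) estimated. Compound 4 is therefore expected to give about 200000 nM, in a range from 80000 nM to 400000 nM.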

Compound 4, half-maximal cytotoxic concentration: 100000 nM
Beside the measured number, compound 4's estimate is 2.0-fold (0.30 log units) above it; measured number inside the range.
By their numbers in this assay, from the lowest: compound 2; then compounds 3 and 4 (each within the scatter of the next). At a limit, above all of these: compound 1.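

Within the data shown here, compound 1 and compound 4 are the first pair here that differ in one place, so the group on the amide-type nitrogen can now be compared directly. In this assay, 2,5-difluorophenyl in place of 2,4,6-trifluorophenyl gives an at least 2.0-fold lower number from compound 1 to compound 4 (0.30 log units; that floor lies within the scatter). The full size of this step stays unknown because the number for compound 1 is only a limit: the limit of > 200000 nM in this assay, at which 1 of the 4 values shown sits.

The compounds shown leave open whether a plain phenyl ring, or a phenyl ring carrying an amine or a carboxylic acid, on this nitrogen would move the number beyond the scatter.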